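Swapping the amide side chain on a piperazine-linked aryl core

This account rests on a few compounds, and the source may have more. Where it says the series, first, only, none or still open, it means among the compounds named here.

Compound 1 `CC(C)C[C@H](N)c1cc(C(F)(F)F)ccc1N1CCN(C(=O)CNc2ccccc2)CC1` is measured in an assay on HEK293 cells for displacement of a labelled ligand from Melanocortin receptor 4 (Homo sapiens) (a lower number here means a stronger inhibitor, a higher number a weaker inhibitor), where compound 1 gives 3600 nM. Compound 2 `Cc1ccc(N2CCN(C(=O)[C@H](C)Cc3ccc(Cl)cc3F)CC2)c([C@@H](N)CC(C)C)c1` shares the aminoalkyl-aryl-piperazine core and in this assay compound 2 gives 20 nM. Among these two numbers compound 1 stands highest, and the gap to compound 2 lies well beyond the usual scatter. Compound 3 `COc1ccc(CC(C)C(=O)N2CCN(c3ccc(C(F)(F)F)cc3[C@@H](N)CC(C)C)CC2)cc1` has not yet been measured; it differs from compound 1 at the carbonyl carbon whose other neighbour is the amide-type nitrogen in a ring: 1-(4-methoxybenzyl)ethyl in place of anilinomethyl on a carbonyl carbon. The new group resembles the branched, benzyl-bearing chain attached at the same place in compound 2, which in this assay gives 20 nM. No step between measured compounds isolates this single change, so a sizeable drop in the number is only plausible, not shown. The step of an 18-fold lower number from compound 1 to compound 3 (1.26 log units; beyond the scatter) is therefore expected to lower the number beyond the scatter, and compound 3 is estimated at 200 nM, within a range of 40 nM to 1000 nM.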

Compound 3, inhibition constant: 120 nM
Compound 3: middle estimate off by 1.7-fold (0.22 log units), on the high side; the measured number falls inside the stated range.
By their numbers in this assay, from the lowest: compound 2; then compound 3; then compound 1.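

Within the data shown here, compound 3 keeps the core of compound 1 and changes only the group on the carbonyl carbon, so this is the first clean reading of that position. In this assay putting 1-(4-methoxybenzyl)ethyl in place of anilinomethyl gives a 30-fold lower number from compound 1 to compound 3 (1.48 log units; beyond the scatter) and shows that this place alone can move the number far beyond the scatter. The entering group has no hydrogen-bond donor and the leaving group has one, but no measurement here explains the change.

From the compounds shown here alone, the swap replaces a whole group at once, so it remains open which part of 1-(4-methoxybenzyl)ethyl matters. A plain benzyl chain, or a hydroxy group in place of the methoxy, would help to separate those parts.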